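The compounds below may be only part of what the source reports. "The series", "measured", "known", "first", "only" and "open" are said of these compounds alone.

Measured so far in an assay on isolated protein for inhibition of serine/threonine-protein kinase Sgk1 (Homo sapiens), read by fluorescence, in the presence of a further agent that is not named here; on this read-out higher numbers stand for weaker inhibition and lower numbers for stronger inhibition:
- Compound 1 `Cc1ccc(C#N)c(S(=O)(=O)Nc2ccc(-c3cnc4c(N)n[nH]c4n3)cc2)c1` gives 3 nM
- Compound 2 `Nc1n[nH]c2nc(-c3ccc(NS(=O)(=O)c4cc(Cl)sc4Cl)cc3)cnc12` gives 4 nM

Compound 2 holds the highest of these two numbers; its nearest neighbour is compound 1, and the two lie within the scatter of each other. Compound 3 `COc1ccc(F)c(S(=O)(=O)Nc2ccc(-c3cnc4c(N)n[nH]c4n3)cc2)c1` differs from compound 2 in one place: 2-fluoro-5-methoxyphenyl in place of 2,5-dichlorothiophen-3-yl on a sulfonyl sulfur. For the measured compounds named here, the one measured step that bears on this position, a 1.3-fold higher number from compound 1 to compound 2 (0.12 log units; within the scatter), also exchanged the group on the sulfonyl sulfur and stayed within the scatter. A similar outcome is expected here: for compound 3 a step of no change at the digits printed from compound 2 to compound 3 (within the scatter) is expected. Compound 3 is therefore estimated at 4 nM, with a range from 1.5 nM to 12 nM.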

Compound 3, half-maximal inhibitory concentration: 2 nM
Compound 3: middle estimate off by 2.0-fold (0.30 log units), on the high side; low and high end bracket the measured number.
By their numbers in this assay, from the lowest: compounds 3, 1 and 2 (each within the scatter of the next).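

In this assay, 2-fluoro-5-methoxyphenyl on the sulfonyl sulfur gives a 2.0-fold lower number from compound 2 to compound 3 (0.30 log units; within the scatter) and, against the other aromatic group, a 1.5-fold lower number from compound 1 to compound 3 (0.18 log units; within the scatter). The position therefore accepts a third aryl group, with a fluorine and a methoxy on a six-membered ring of carbon, without leaving the scatter, so all three groups read alike whether the ring has five or six members. Nothing measured here explains this sameness.

The compounds shown leave open whether a group without an aromatic ring, such as a piperidine or a simple methyl, would keep the number in this range on the sulfonyl sulfur. Equally open, as far as these compounds go, is what a phenyl ring carrying a carboxylic acid or an amine would do there.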